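From Phenyl to Pyridin-3-yl on a Shared Core

A few compounds are considered here, and "the series" means these few. Any claim that something is new, unique, unknown or untested is made for them only; others in the source may bear on it.

- Compound 1 `CC1(C)Oc2ccc(C#N)cc2[C@@H](/N=C(\NC#N)Nc2ccccc2)[C@@H]1O`: 1400 nM; 1300 nM (2 entries)
- Compound 2 `CC1(C)Oc2ccc(C#N)cc2[C@@H](NC(=O)Nc2ccccc2)[C@@H]1O`: 800 nM
- Compound 3 `CC1(C)Oc2ccc(C#N)cc2[C@@H](/N=C(\NC#N)Nc2ccc(N)cc2)[C@@H]1O`: 3500 nM

These three compounds were tested in a functional assay (aorta) with Rattus norvegicus as the target; on this read-out higher numbers stand for weaker inhibition and lower numbers for stronger inhibition. Repeat testing of compound 1 gave close agreement, as the several entries of compound 1 in this assay, 1400 nM; 1300 nM (2 entries) shows. Compound 2, at 800 nM, has a lower number than compound 3, at 3500 nM, and this gap lies beyond the usual scatter. Compound 2 is therefore the starting point for a closer look, with a number that marks comparatively strong inhibition within this small set.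

The next compound, compound 4 `CC1(C)Oc2ccc(C#N)cc2[C@@H](NC(=O)Nc2cccnc2)[C@@H]1O`, differs from compound 2 in one place: pyridin-3-yl in place of phenyl on an amide-type nitrogen, (pyridin-3-yl in place of phenyl on an amide-type nitrogen). Within the data shown here, no measured pair shows this exact change, so any forecast is uncertain. The nearest hint comes from compound 3, at 3500 nM, which has an amino group on its aromatic ring and shows a higher number than compound 1, at 1400 nM; 1300 nM (2 entries). Changes to this ring may therefore affect the read-out, although the two cases are not the same.

The expected change is a 1.6-fold higher number from compound 2 to compound 4 (0.21 log units; within the scatter), a small rise in the number that stays within the scatter. For compound 4, the estimated value in this assay is 1300 nM, with an expected range from 450 nM to 3800 nM.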

Compound 4, half-maximal inhibitory concentration: 500 nM
The estimate for compound 4 lay 2.6-fold (0.41 log units) above the measured number, within the range that was stated.
By their numbers in this assay, from the lowest: compounds 4 and 2 (each within the scatter of the next); then compound 3.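

In this assay, placing pyridin-3-yl instead of phenyl on the amide-type nitrogen gives a 1.6-fold lower number from compound 2 to compound 4 (0.20 log units; within the scatter), so this read-out cannot tell the two compounds apart. Among these compounds, this is the first direct view of this change: the aromatic ring at this place can carry a ring nitrogen, and with it one hydrogen-bond acceptor by the count for the two groups, without a step beyond the usual scatter. The compounds shown offer no measurement that explains why the swap leaves the number within the scatter, so the result describes what happened at this place and not its cause.

As far as these compounds go, this is a single pair, so it remains open whether the same tolerance extends to other rings on this nitrogen, such as pyridin-4-yl or pyrimidin-5-yl, or to a non-aromatic group such as cyclohexyl. From the compounds shown here alone, it also remains open whether pyridin-3-yl would behave the same way on compound 1, which has the same phenyl group but a cyano-bearing link in place of the carbonyl of compound 2.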